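The source may hold more compounds than are shown below. What is called first, only, known or untested is meant among the compounds shown, and "the series" means these compounds.

Measured compounds in a functional assay on MIA PaCa-2 cells (Homo sapiens) for inhibition, read by MTT assay, with a stated time of 7 days; a lower number here means a stronger inhibitor, a higher number a weaker inhibitor:
compound 1 `CCN(CC)S(=O)(=O)c1ccc(S(=O)(=O)N2CCC[C@@H](C(=O)N[C@H]3CC[C@H](OC)CC3)C2)cc1`, 1350 nM
compound 2 `CCC(CC)S(=O)(=O)c1ccc(S(=O)(=O)N2CCC[C@@H](C(=O)N3CCC(F)(F)CC3)C2)cc1`, 13 nM
compound 3 `CCN(CC)S(=O)(=O)c1ccc(S(=O)(=O)N2CCC[C@@H](C(=O)N3CCC(OC)CC3)C2)cc1`, 140 nM

Compound 2 gives the lowest number of the three in this assay, and its steps to compound 3 and to compound 1 both lie beyond the scatter, so it is the strongest inhibitor among them. For the measured compounds named here, the one directly comparable step, a 9.6-fold lower number from compound 1 to compound 3 (0.98 log units; beyond the scatter), concerns the amide end of the shared core and not the sulfonyl end.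

Compound 4 `O=C([C@@H]1CCCN(S(=O)(=O)c2ccc(S(=O)(=O)C3COC3)cc2)C1)N1CCC(F)(F)CC1` differs from compound 2 at the other end: oxetan-3-yl in place of pentan-3-yl on a sulfonyl sulfur. Going by the values given here, no measured pair among compounds 1, 2 and 3 changes the group on that sulfonyl sulfur, so no step bears directly on this change; compounds 1 and 3 carry a different substituent there and also differ from compound 2 at the amide. The expectation therefore rests on compound 2 alone, with wide uncertainty. A modest rise in the number is expected, as a 3.1-fold higher number from compound 2 to compound 4 (0.49 log units; beyond the scatter), since the entering group is smaller and of a different kind. Compound 4 is estimated at 40 nM, within 10 nM to 200 nM.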

Compound 4, half-maximal inhibitory concentration: 110 nM
Compound 4: middle estimate off by 2.8-fold (0.44 log units), on the low side; the measured number falls inside the stated range.
By their numbers in this assay, from the lowest: compound 2; then compounds 4 and 3 (each within the scatter of the next); then compound 1.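

In this assay, the group on the sulfonyl sulfur matters in its own right: with the rest of compound 2 unchanged, oxetan-3-yl in place of pentan-3-yl gives an 8.5-fold higher number from compound 2 to compound 4 (0.93 log units; beyond the scatter). The number therefore responds to a change at this end of the shared core, as a 9.6-fold lower number from compound 1 to compound 3 (0.98 log units; beyond the scatter) had shown for the amide end, and in this pair the open-chain pentan-3-yl gives the lower number. Nothing measured here gives a reason for this difference.

For the compounds shown here, the single pair cannot say whether the ring or its oxygen goes with the higher number, a distinction that a cyclobutyl group on the same sulfonyl sulfur could draw. It also leaves open whether the step would keep its size with a different group at the amide end.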